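Chlorophenyl exchange on the saturated ring carbon: notes

The compounds below may be only part of what the source reports. "The series", "measured", "known", "first", "only" and "open" are said of these compounds alone.

Measured so far in an ADME assay on Vero 76 cells (Chlorocebus sabaeus) for cytotoxicity, read by MTT assay, with a stated time of 96 h; a higher number here means that more compound is tolerated, a lower number that less compound is tolerated:
- compound 1 `Cc1ccc(C2CC(c3ccc(Oc4ccccc4)cc3)=NN2c2ccc(S(N)(=O)=O)cc2)cc1`: 86000 nM
- compound 2 `NS(=O)(=O)c1ccc(N2N=C(c3ccc(Oc4ccccc4)cc3)CC2c2cccc(Cl)c2)cc1`: 88000 nM

Compound 2, at 88000 nM in these notes, lies within the scatter of compound 1, so neither of the two values stands apart.

The next structure is compound 3 `NS(=O)(=O)c1ccc(N2N=C(c3ccc(Oc4ccccc4)cc3)CC2c2ccc(Cl)cc2)cc1`, which differs from compound 2 in one group: 4-chlorophenyl in place of 3-chlorophenyl on a saturated ring carbon. The exchange sits on a saturated ring carbon, next to the ring nitrogen.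

Among the compounds with values here, one measured step bears on it: a 1.0-fold higher number from compound 1 to compound 2 (0.01 log units; within the scatter) at that same ring carbon. That step replaces a 4-methylphenyl group and does not isolate the exchange of 3-chlorophenyl for 4-chlorophenyl, so the evidence is thin. Within the data shown here, no measured pair shows that exchange directly.

On this basis, no step beyond the scatter is expected in this assay, and the estimated change is a 1.0-fold lower number from compound 2 to compound 3 (0.02 log units; within the scatter) as a working figure. For compound 3 the expected value is 85000 nM within an estimated range of 45000 nM to 130000 nM for now.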

Compound 3, half-maximal cytotoxic concentration: 88000 nM
Compound 3: middle estimate off by 1.0-fold (0.02 log units), on the low side, within the range that was stated.
By their numbers in this assay, from the lowest: compounds 1, 2 and 3 (each within the scatter of the next).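

In this assay, the exchange of 3-chlorophenyl for 4-chlorophenyl on the saturated ring carbon is now read directly, as no change at the digits printed from compound 2 to compound 3 (within the scatter), so the place of the chloro on this phenyl group makes no difference beyond the scatter between these two compounds. The exchange of chloro for methyl on the aromatic carbon, with the para-free wording of the group names kept as 4-chlorophenyl against 4-methylphenyl, gives a 1.0-fold higher number from compound 1 to compound 3 (0.01 log units; within the scatter), which supplies a direct comparison that compound 2 could not give, and together with a 1.0-fold higher number from compound 1 to compound 2 (0.01 log units; within the scatter) it leaves all three aryl groups at this ring carbon within the scatter of one another. No measurement is at hand that would account for this flat result.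

The compounds shown carry only a chloro or a methyl on this phenyl group, so it remains open whether an amine or a carboxylic acid there would leave the tolerated concentration where it stands. Also open, going by these compounds, is whether a longer alkyl chain or a morpholine in place of the whole aryl group at this ring carbon would hold to the same level.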